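Methoxy position on the cinnamate ring and whole-animal effect

The compounds below may be only part of what the source reports. "The series", "measured", "known", "first", "only" and "open" are said of these compounds alone.

Measured so far:
compound 1 `COc1ccccc1/C=C/C(=O)OC/C=C/c1cc(OC)c(OC)cc1OC`: 100%
compound 2 `COc1cc(OC)c(OC)cc1/C=C/COC(=O)/C=C/c1c(OC)ccc(OC)c1OC`: 100%

In a functional assay on the whole organism (strain Kunming) with Mus musculus as the target, with a stated time of 0.5 h, at a dose of 100 mg/kg by the intraperitoneal route (a higher number here means a weaker effect of the compound at the dose given, a lower number a stronger effect), compound 1 gives 100%. Compound 2 gives 100% in this assay, so the two stand level at the digits shown, and no order between them can be read from these numbers. Among the compounds with values here, compound 1 therefore stands at the same point as its only measured neighbour, and there is no step between measured compounds from which the size of any structural change could be read.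

Compound 3 `COc1cccc(/C=C/C(=O)OC/C=C/c2cc(OC)c(OC)cc2OC)c1` differs from compound 1 by 3-methoxyphenyl in place of 2-methoxyphenyl on a double-bonded chain carbon bound to a double-bonded chain carbon. Nothing measured here shows how such a change moves the read-out in this assay. With both measured compounds at the same value, the step is expected to be none beyond the scatter, and the step of no change at the digits printed from compound 1 to compound 3 (within the scatter) is estimated accordingly. Compound 3 is expected to give about 100% in this assay, within a range of 82% to 106%.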

Compound 3, a percentage reported as activity, at one dose (the size of the read-out at that dose, not a potency): 100%
Compound 3: the middle estimate sits on the measured number at the digits printed; low and high end bracket the measured number.
By their numbers in this assay, from the lowest: compounds 1, 2 and 3 (each within the scatter of the next).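

In this assay, within the data shown here, 3-methoxyphenyl in place of 2-methoxyphenyl on a double-bonded chain carbon bound to a double-bonded chain carbon gives no change at the digits printed from compound 1 to compound 3 (within the scatter), and this is the first step between measured compounds that differ in one place. It shows that, at this dose and time, the read-out does not separate these two methoxyphenyl groups at this place. Nothing at hand offers an explanation of this result.

On these data alone, whether an amine, a carboxylic acid or a longer chain at this place would move the read-out remains open. Also open, as far as these compounds go, is whether any change elsewhere on the core of compound 1 would bring the number down, since a single step says nothing about other places.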